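Swapping an aromatic tail for a short chain

The compounds below may be only part of what the source reports. "The series", "measured", "known", "first", "only" and "open" are said of these compounds alone.

Compound 1 `O=C(CN1C(=O)/C(=C/c2ccc(-c3ccc(Cl)cc3)o2)SC1=S)NCc1ccc(C(F)(F)F)cc1`: 155000 nM
Compound 2 `O=C(CN1C(=O)/C(=C/c2ccc(-c3ccc(Cl)cc3)o2)SC1=S)NCc1ccc(F)cc1`: 150000 nM
Compound 3 `Cc1ccc(CNC(=O)CN2C(=O)/C(=C/c3ccc(-c4ccc(Cl)cc4)o3)SC2=S)cc1`: 45000 nM

These three compounds were tested in a functional assay on K562 cells (Homo sapiens) for cytotoxicity, read by MTT assay, with a stated time of 72 h; a higher number here means a weaker inhibitor, a lower number a stronger inhibitor. Compound 2 stands second highest of the three: one of its steps, a 1.0-fold lower number from compound 1 to compound 2 (0.01 log units; within the scatter), lies within the scatter, while the other, a 3.3-fold lower number from compound 2 to compound 3 (0.52 log units; beyond the scatter), lies beyond it. Compound 4 `CCCNC(=O)CN1C(=O)/C(=C/c2ccc(-c3ccc(Cl)cc3)o2)SC1=S` has not yet been measured. Its change from compound 2 is ethyl in place of 4-fluorophenyl on a saturated chain carbon bound to an amide-type nitrogen. Going by the values given here, each measured step only swapped one group for another on an aromatic carbon, and the largest shift, a 3.4-fold lower number from compound 1 to compound 3 (0.54 log units; beyond the scatter), was modest; none removed the ring itself, so no measured step bears directly on this change. A small step is therefore expected, with little confidence in its direction: a 1.1-fold higher number from compound 2 to compound 4 (0.05 log units; within the scatter). Compound 4 is estimated in this assay at 170000 nM, in the range 50000 nM to 500000 nM.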

Compound 4, half-maximal inhibitory concentration: 50000 nM
Beside the measured number, compound 4's estimate is 3.4-fold (0.53 log units) above it; measured number inside the range.
By their numbers in this assay, from the lowest: compounds 3 and 4 (each within the scatter of the next); then compounds 2 and 1 (each within the scatter of the next).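

In this assay the aromatic ring at this position can be given up: with ethyl in its place, the shift is a 3.0-fold lower number from compound 2 to compound 4 (0.48 log units; beyond the scatter) and a 3.1-fold lower number from compound 1 to compound 4 (0.49 log units; beyond the scatter), both modest gains, while a 1.1-fold higher number from compound 3 to compound 4 (0.05 log units; within the scatter) shows no real change. A short chain on a saturated chain carbon bound to an amide-type nitrogen therefore does as well here as the 4-methylphenyl tail of compound 3. Nothing measured here gives a reason for this. Still open, on these data alone, is how a longer chain such as butyl would behave. Also open, as far as these compounds go, is the effect of an amine or a carboxylic acid at the end of this chain.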